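The compounds below may be only part of what the source reports. "The series", "measured", "known", "first", "only" and "open" are said of these compounds alone.

Compound 1 `COc1cccc(Oc2ccc3c(NCCCNCc4ccco4)ccnc3c2)c1` was tested in an ADME assay on HepG2 cells (Homo sapiens) for cytotoxicity, read by luminescence, CellTiter-Glo and ATP content, with a stated time of 72 h (a lower number here means that less compound is needed, a higher number that more compound is needed for the effect), where compound 1 gives 15500 nM, the highest of the two numbers recorded; its nearest neighbour is compound 2 `COc1cccc(Oc2ccc3c(NCCCNCc4cccc(OC)c4O)ccnc3c2)c1`, and in this assay compound 2 gives 5300 nM. Among the measured compounds shown here, the single measured step, a 2.9-fold lower number from compound 1 to compound 2 (0.47 log units; beyond the scatter), changes the group on a saturated chain carbon bound to an amine nitrogen and leaves the oxygen on the aromatic ring untouched. Compound 3 `COc1ccccc1Oc1ccc2c(NCCCNCc3ccco3)ccnc2c1` differs from compound 1 at that other site: 2-methoxyphenyl in place of 3-methoxyphenyl on an oxygen on an aromatic ring. For the measured compounds named here, no measured step touches this part of the molecule, so the two measurements give no indication of which way, if at all, the change moves the number in this assay. The step of no change at the digits printed from compound 1 to compound 3 (within the scatter) is therefore expected to stay within the scatter. The estimate for compound 3 in this assay is 15500 nM, with a range from 6000 nM to 40000 nM.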

Compound 3, half-maximal effective concentration: 6500 nM
For compound 3 the middle estimate is 2.4-fold (0.38 log units) above the measured one; low and high end bracket the measured number.
By their numbers in this assay, from the lowest: compounds 2 and 3 (each within the scatter of the next); then compound 1.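

Replacing 3-methoxyphenyl with 2-methoxyphenyl on the oxygen on an aromatic ring gives a 2.4-fold lower number from compound 1 to compound 3 (0.38 log units; beyond the scatter) in this assay and so shows that this site is not silent, even though the two groups have the same atoms and the same counts. The earlier compounds shown here showed a shift only from the group on the saturated chain carbon bound to an amine nitrogen, whereas here the furan-2-yl end stays the same and the placement of the methoxy alone moves the number. No evidence is available that bears on this shift. On these data alone, whether the same change would act alike with 2-hydroxy-3-methoxyphenyl in place of furan-2-yl stays open. Also open, as far as these compounds go, is what a plain phenyl, or an ethoxy group in place of the methoxy, would give on that oxygen.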